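This account rests on a few compounds, and the source may have more. Where it says the series, first, only, none or still open, it means among the compounds named here.

The measured compounds and their values:
- compound 1, `COC1=C(C)C(=O)/C(=C(O)/C=C/c2ccc(O)cc2)C(=O)C1(C)C`: 3.1 ug/mL
- compound 2, `CCc1ccc(/C=C/C(O)=C2/C(=O)C(C)=C(OC)C(C)(C)C2=O)cc1`: 6.1 ug/mL
- compound 3, `C=Cc1ccccc1/C=C/C(O)=C1/C(=O)C(C)=C(OC)C(C)(C)C1=O`: 2.2 ug/mL

In a functional assay on A549 cells (Homo sapiens) for cytotoxicity (on this read-out higher numbers stand for an effect only at larger amounts of compound and lower numbers for an effect already at smaller amounts), compound 1 stands second highest among the three numbers; its nearest neighbour is compound 3, reached by a 1.4-fold lower number from compound 1 to compound 3 (0.15 log units; within the scatter), and its furthest is compound 2, reached by a 2.0-fold higher number from compound 1 to compound 2 (0.29 log units; within the scatter). Neither of these steps leaves the scatter.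

Compound 4, `COC1=C(C)C(=O)/C(=C(O)/C=C/c2nccs2)C(=O)C1(C)C`, has not yet been measured. It differs from compound 1 in one place: 1,3-thiazol-2-yl in place of 4-hydroxyphenyl on a double-bonded chain carbon bound to a double-bonded chain carbon. For the measured compounds named here, the steps that bear on such an exchange of the aromatic group on the double-bonded chain carbon are a 1.4-fold lower number from compound 1 to compound 3 (0.15 log units; within the scatter) and a 2.8-fold lower number from compound 2 to compound 3 (0.44 log units; beyond the scatter); of these only the second goes beyond the scatter, and even that one is modest. The shared core is untouched in every compound here. Swapping the aromatic group has so far moved this assay by small amounts only, so the step from compound 1 to compound 4 is expected to be small as well, with no clear direction, and is estimated as a 1.3-fold higher number from compound 1 to compound 4 (0.11 log units; within the scatter). Compound 4 is therefore expected to give about 4 ug/mL in this assay, within a range from 1.5 ug/mL to 10 ug/mL.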

Compound 4, concentration for half-maximal effect: 3.5 ug/mL
Beside the measured number, compound 4's estimate is 1.1-fold (0.06 log units) above it; the range from low to high includes it.
By their numbers in this assay, from the lowest: compounds 3, 1, 4 and 2 (each within the scatter of the next, the first and the last beyond it).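

In this assay, for the compounds shown here, the place on a double-bonded chain carbon bound to a double-bonded chain carbon now also holds 1,3-thiazol-2-yl, a five-membered aromatic ring with 2 hetero atoms, where the earlier compounds all carried a six-membered aromatic ring of carbon only, and the exchange gives a 1.1-fold higher number from compound 1 to compound 4 (0.05 log units; within the scatter) and also a 1.6-fold higher number from compound 3 to compound 4 (0.20 log units; within the scatter) and a 1.7-fold lower number from compound 2 to compound 4 (0.24 log units; within the scatter) without any of these steps leaving the scatter. Among these four compounds, then, a six-membered carbon ring is not needed at this place for a number in this range, and the one step beyond the scatter remains the one between the two compounds with substituted phenyl groups that carry no hydroxy, compound 2 and compound 3. Nothing at hand explains why such different aromatic groups give such similar numbers.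

As far as these compounds go, whether this tolerance extends to a group that is not aromatic, such as cyclohexyl or a longer alkyl chain, or to a phenyl ring carrying an amine or a carboxylic acid, stays open. Also open, from the compounds shown here alone, is how the read-out responds to a change in the shared core, which is the same in all four compounds, for instance an ethoxy group in place of its methoxy group.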